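The compounds below may be only part of what the source reports. "The series", "measured", "known", "first", "only" and "open" are said of these compounds alone.

Compound 1 `Cc1ccc(O)c(C(=O)/C=C/c2cn(-c3ccc(F)cc3)nc2-c2sc(C)nc2C)c1` gives 47.8 ug/mL in an ADME assay on A549 cells (Homo sapiens) for inhibition, read by MTT assay; on this read-out higher numbers stand for weaker inhibition of growth and lower numbers for stronger inhibition of growth. Compound 2 `Cc1nc(C)c(-c2nn(-c3ccc(F)cc3)cc2C2CC(c3cc(Cl)ccc3O)=NN2)s1` stands apart in this assay, where compound 2 gives only a limit of the assay, > 250 ug/mL, and not a number. What is known of compound 2 here is therefore (the limit of > 250 ug/mL in this assay, at which 1 of the 2 values shown sits). Compound 3 `Cc1nc(C)c(-c2nn(-c3ccc(F)cc3)cc2C2CC(c3c(O)cc(C)c(Cl)c3C)=NN2)s1` has not yet been measured in this assay. It differs from compound 2 in one place: 3-chloro-6-hydroxy-2,4-dimethylphenyl in place of 5-chloro-2-hydroxyphenyl on a carbon with a double bond to nitrogen. Within the data shown here, no measured pair of compounds shares this change, so no measured step is available to guide the expectation. Because compound 2 gave > 250 ug/mL, compound 3 is expected to remain near that limit, with no step beyond the scatter, so the expected step is a number no higher from compound 2 to compound 3 (the limit leaves the size open). For compound 3 the estimate in this assay is 250 ug/mL, expected to lie between 80 ug/mL and 600 ug/mL.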

Compound 3, concentration for 50% growth inhibition: 43.4 ug/mL
Estimate against measurement, compound 3: 5.8-fold (0.76 log units) above, outside the stated range (below it).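

In this assay, the position on a carbon with a double bond to nitrogen of the five-membered non-aromatic ring proves able to change the read-out: 3-chloro-6-hydroxy-2,4-dimethylphenyl in place of 5-chloro-2-hydroxyphenyl gives an at least 5.7-fold lower number from compound 2 to compound 3 (0.76 log units; beyond the scatter), which means stronger inhibition of growth. The entering group has 10 heavy atoms against 8 in the group it replaces, and it keeps the same counted hydrogen-bond donor and acceptor. Compound 2 gives only a limit of the assay, so the full size of this step cannot be read: the limit of > 250 ug/mL in this assay, at which 1 of the 3 values shown sits.

The compounds shown leave open which part of the new aryl group carries the step, since the two methyl groups arrive together and the chlorine is placed differently in the same change. They also leave open how this position would respond if the hydroxy group gave way to a methoxy group or an amine.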